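Swapping the pyridine for a plain benzene ring

This account rests on a few compounds, and the source may have more. Where it says the series, first, only, none or still open, it means among the compounds named here.

Measured compounds:
- compound 1 `CCN(CC)c1ccc(C(F)(F)F)cc1NC(=O)c1cccnc1`: 63200 nM
- compound 2 `O=C(Nc1cc(C(F)(F)F)ccc1NC1CCCCC1)c1ccccc1`: "not active" (no number reported)
- compound 3 `CCN(CC)c1ccc(C(F)(F)F)cc1NC(=O)c1ccncc1`: 63600 nM

In a functional assay on NALM-6 cells (Homo sapiens) for cytotoxicity, read by MTT assay, with a stated time of 48 h (on this read-out higher numbers stand for weaker inhibition and lower numbers for stronger inhibition), compound 3 gives the higher of the two numbers reported, with compound 1 sitting within the scatter of it; compound 2 has no number and is simply called "not active" (no number reported). The next compound, compound 4 `CCN(CC)c1ccc(C(F)(F)F)cc1NC(=O)c1ccccc1`, differs from compound 3 by phenyl in place of pyridin-4-yl on a carbonyl carbon. For the measured compounds named here, only one measured step touches this carbonyl-bound ring: a 1.0-fold higher number from compound 1 to compound 3 (0.00 log units; within the scatter), which moved nothing beyond the scatter. Going by the values given here, no measured pair shows a pyridine-to-benzene swap on the same core, and compound 2 carries a benzoyl group on a different amine, so it does not settle the point. Compound 4 is therefore expected to stay close to compound 3, with the step of a 1.1-fold higher number from compound 3 to compound 4 (0.04 log units; within the scatter) estimated as lying within the scatter, and its value estimated at 70000 nM, ranging from 30000 nM to 160000 nM.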

Compound 4, half-maximal inhibitory concentration: "not active" (no number reported)
Nothing numeric was reported for compound 4; there is nothing to compare the estimate with.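

For the compounds shown here, compound 4 carries only the words "not active", without a number, and no step from compound 3 to compound 4 can be read. Nothing shown accounts for that label. Left open is whether swapping pyridin-4-yl for phenyl truly changes cytotoxicity on this core.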